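Three Limits and a Benzyl Amide

The source may hold more compounds than are shown below. What is called first, only, known or untested is meant among the compounds shown, and "the series" means these compounds.

Compound 3 (`COc1cccc(NC(=O)CSc2nnc(-c3cc(OC)c(OC)c(OC)c3)n2N)c1`) carries the shared core with a (3-methoxyphenyl)amino group on its carbonyl carbon. In a functional assay on HepG2 cells (Homo sapiens) for antiproliferative activity, read by MTT assay, with a stated time of 48 h (a lower number here means a stronger inhibitor, a higher number a weaker inhibitor), compound 3 reaches only the limit of the assay, > 100000 nM. Its two measured relatives stand no better. Compound 1 (`COc1cc(-c2nnc(SCC(=O)c3ccc(C(F)(F)F)cc3)n2N)cc(OC)c1OC`) gives > 100000 nM in this assay, which is a limit. Compound 2 (`COc1cc(-c2nnc(SCC(=O)c3ccc(F)c(F)c3)n2N)cc(OC)c1OC`) likewise gives > 100000 nM, again a limit. The steps a step that the two limits leave unreadable from compound 1 to compound 2, a step that the two limits leave unreadable from compound 1 to compound 3 and a step that the two limits leave unreadable from compound 2 to compound 3 are therefore all unreadable, as the limit of > 100000 nM in this assay, at which 3 of the 3 values shown sit, records. Compound 4 (`COc1cc(-c2nnc(SCC(=O)NCc3ccc(Cl)cc3)n2N)cc(OC)c1OC`) differs from compound 3 by 4-chlorobenzyl in place of 3-methoxyphenyl on an amide-type nitrogen. Among the measured compounds shown here, no measured step bears on this change, and every value gathered so far sits at the limit, so compound 4 is expected to remain there, with a step that the limit leaves unreadable from compound 3 to compound 4 meaning no readable step. Compound 4 is accordingly estimated at 150000 nM in this assay, within 30000 nM to 600000 nM, and most probably reported once more as a limit rather than a number.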

Compound 4, half-maximal inhibitory concentration: > 100000 nM
Compound 4: a limit, no number (the forecaster's own chance of this, stated with the estimate: 80%); the middle value is on the limit's open side.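

Compound 4 also stops at a limit, not a number, so its steps from compound 1, compound 2 and compound 3 cannot be read: the limit of > 100000 nM in this assay, at which 4 of the 4 values shown sit.

The compounds shown leave open which change to the shared core, if any, would bring a measurable number in this assay.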